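Working notes: from compound 3 to compound 4

The source may hold more compounds than are shown below. What is called first, only, known or untested is meant among the compounds shown, and "the series" means these compounds.

Values in a functional assay on MCF7 cells (Homo sapiens) for cytotoxicity, read by sulforhodamine B assay, with a stated time of 48 h; a higher number here means a weaker inhibitor, a lower number a stronger inhibitor:
- compound 1 `COc1ccc2c(c1)c(C=O)cn2Cc1cn([C@@H]2O[C@H](COC(C)=O)[C@@H](OC(C)=O)[C@H](OC(C)=O)[C@H]2OC(C)=O)nn1`: > 200000 nM (a limit)
- compound 2 `COc1ccc2c(c1)c(/C=N/O)cn2Cc1cn([C@@H]2O[C@H](COC(C)=O)[C@@H](OC(C)=O)[C@H](OC(C)=O)[C@H]2OC(C)=O)nn1`: 51000 nM
- compound 3 `CC(=O)OC[C@H]1O[C@@H](n2cc(Cn3cc([N+](=O)[O-])c4ccccc43)nn2)[C@H](OC(C)=O)[C@@H](OC(C)=O)[C@@H]1OC(C)=O`: > 200000 nM (a limit)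

Compound 3 stands at the limit of > 200000 nM in this assay, at which 2 of the 3 values shown sit. Its entry is a limit and not a number, so any step starting from it can only be read loosely.

Among the compounds with values here, the next compound, compound 4 `CC(=O)OC[C@H]1O[C@@H](n2cc(Cn3cc(/C=C4/C(=O)Nc5ccccc54)c4ccccc43)nn2)[C@H](OC(C)=O)[C@@H](OC(C)=O)[C@@H]1OC(C)=O`, has no measurement yet in this assay. The structural change is a group of 11 heavy atoms (9 carbon, 1 nitrogen, 1 oxygen; one five-membered non-aromatic ring with 1 hetero atom, one six-membered aromatic ring of carbon only) in place of a group of 3 heavy atoms (1 nitrogen, 2 oxygen; no ring), on an aromatic carbon.

Within the data shown here, the one measured step that bears on this is an at least 3.9-fold lower number from compound 1 to compound 2 (0.59 log units; beyond the scatter). It too replaces a group on an aromatic carbon, though with a much smaller group than the one entering here. Among the measured compounds shown here, compound 2, at 51000 nM, is the only compound of the three with a number. On that single step, a modest move towards a lower number is expected in this assay, and a result that stays at the limit remains possible.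

The expected change, an estimate only, is an at least 4.0-fold lower number from compound 3 to compound 4 (0.60 log units; beyond the scatter). For compound 4 the expected value is 50000 nM, with an estimated range from 10000 nM to 200000 nM.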

Compound 4, half-maximal inhibitory concentration: 22200 nM
The estimate for compound 4 lay 2.3-fold (0.35 log units) above the measured number; the measured number falls inside the stated range.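

In this assay, the nitro group on the aromatic carbon of the five-membered ring gives way to a much larger group with two rings, and the result is an at least 9.0-fold lower number from compound 3 to compound 4 (0.95 log units; beyond the scatter). Within the data shown here, the earlier step, an at least 3.9-fold lower number from compound 1 to compound 2 (0.59 log units; beyond the scatter), involved only ring-free groups on an aromatic carbon, so this is the first sign that a group carrying a five-membered non-aromatic ring and a six-membered aromatic ring can enter at such a carbon and still give a measurable value in this assay. The size of the new step is only a lower bound, as the entry for compound 3 is a limit and not a number: the limit of > 200000 nM in this assay, at which 2 of the 4 values shown sit.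

Going by these compounds, it remains open whether the lower number depends on the whole entering group or only on part of it, such as the ring amide or the exocyclic double bond. An amine or a carboxylic acid on the same aromatic carbon would help separate the effect of the two-ring group from the loss of nitro, and a compound with free hydroxyls in place of the acetates would show how much the sugar esters contribute.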